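Extending a Silent Pair by a Silicon-Bearing Group

The source may report more compounds than this note shows. Statements on the series, on what has been measured and on what is new or still open speak of the compounds shown alone.

Compound 1 `O=c1cc(CC(O)COCc2ccccc2)[nH]c(=O)[nH]1` in a functional assay on HepG2 cells (Homo sapiens) for antiproliferative activity, read by MTT assay, with a stated time of 72 h (on this read-out higher numbers stand for weaker inhibition and lower numbers for stronger inhibition), gives > 100000 nM, which is a limit of the assay and not a number.
Compound 2 `Cc1c(CC(O)COCc2ccccc2)[nH]c(=O)[nH]c1=O` in this assay gives > 100000 nM, again a limit rather than a number.

Since the limit of > 100000 nM in this assay, at which 2 of the 2 values shown sit, covers the whole measured pair, the step that the two limits leave unreadable from compound 1 to compound 2 stays unreadable, and compound 2 stands only as a limit. Compound 3 `Cc1c(CC(O)COCc2ccccc2)n(COCC[Si](C)(C)C)c(=O)[nH]c1=O` differs from compound 2 by a group of 8 heavy atoms (6 carbon, 1 oxygen, 1 silicon; no ring) in place of a hydrogen atom, on an aromatic nitrogen. Going by the values given here, no measured step bears on this kind of change, and the one available step is itself unreadable, so the expectation rests on two limits alone. Compound 3 is expected to give 100000 nM (from 30000 nM to 300000 nM) in this assay. This means an estimated step of a number no higher from compound 2 to compound 3 (the limit leaves the size open), expected to be none beyond the scatter.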

Compound 3, half-maximal inhibitory concentration: > 100000 nM
Compound 3: only a limit was reported (the forecaster's own chance of this, stated with the estimate: 80%); the middle value sits exactly at the limit.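

No step can be read between compound 2 and compound 3, since each gives only a limit and not a number: the limit of > 100000 nM in this assay, at which 3 of the 3 values shown sit.

In this assay the compounds shown leave open how strongly any of them inhibits and what either change does.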